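Does the Methyl Matter? From Compound 2 to Compound 3

The source may report more compounds than this note shows. Statements on the series, on what has been measured and on what is new or still open speak of the compounds shown alone.

Of the compounds shown here, two have been measured in a functional assay on HeLa cells (Homo sapiens) for cytotoxicity, read by MTT assay, with a stated time of 72 h, tested at 30 uM; a lower number here means less inhibition of growth, a higher number more inhibition of growth at the concentration tested. Compound 1 `Cc1cccc(/C(N)=N/NC(=S)N2CCN(c3ccccn3)CC2)n1` gives 86.3% in this assay. Compound 2 `Cc1cccc(/C(N)=N/NC(=S)N2CCSCC2)n1` gives 85.3%, a number that lies within the usual scatter of that of compound 1, so the two cannot be told apart on these measurements. Compound 3 `N/C(=N\NC(=S)N1CCSCC1)c1ccccn1` has not yet been measured. It differs from compound 2 in one place: hydrogen in place of methyl on an aromatic carbon. For the measured compounds named here, no step between two measured compounds matches this change, so its effect has to be judged from the change itself. Only the methyl is removed, and both measured compounds show strong growth inhibition, so the step of a number 5.3 percentage points lower from compound 2 to compound 3 (within the scatter) is expected to be small, a modest fall that may not exceed the scatter. Compound 3 is therefore expected to give about 80% in this assay, with a range from 60% to 92%.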

Compound 3, percent growth inhibition at one concentration: 80.6%
Compound 3: the middle estimate sits 0.6 percentage points below what was measured, and the stated range covers the measured number.
By their numbers in this assay, from the lowest: compounds 3, 2 and 1 (each within the scatter of the next).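

For the compounds shown here, this is the first readable step at this position, an aromatic carbon next to the ring nitrogen. In this assay, hydrogen in place of methyl gives a number 4.7 percentage points lower from compound 2 to compound 3 (within the scatter) and so shows that, on these measurements, the methyl is not needed for compound 3 to inhibit growth strongly at the concentration tested. Because this is a reading at one concentration, it cannot show whether the two compounds would also match at lower concentrations, and no measurement offered here accounts for the result.

Still open, as far as these compounds go, is what a different group on this carbon, such as an amine, a methoxy group or a longer chain, would do to the number. Also open, from the compounds shown here alone, is whether the same change would give so small a step on compound 1.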